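Swapping the aryl group on the piperazine for a pyrimidine

The source may report more compounds than this note shows. Statements on the series, on what has been measured and on what is new or still open speak of the compounds shown alone.

Measured compounds so far:
- compound 1, `CC1(c2ccccc2)CC(=O)N(CC(=O)N2CCN(c3cccc(C(F)(F)F)c3)CC2)C1=O`: 300 mg/kg
- compound 2, `CC1(c2ccccc2)CC(=O)N(CC(=O)N2CCN(c3ccc(Cl)cc3)CC2)C1=O`: "not active" (no number reported)
- compound 3, `CC1(c2ccccc2)CC(=O)N(CC(=O)N2CCN(c3cccc(Cl)c3)CC2)C1=O`: 300 mg/kg

In a functional assay on the whole organism (strain CD-1) with Mus musculus as the target, in the maximal electroshock model, with a stated time of 0.5 h (on this read-out lower numbers stand for an effect already at smaller amounts and higher numbers for an effect only at larger amounts of compound), compound 1 gives 300 mg/kg, and compound 3 gives 300 mg/kg, so compound 1 stands level with compound 3 at the digits shown. Among the measured compounds shown here, the only step between measured compounds, no change at the digits printed from compound 1 to compound 3 (within the scatter), comes from a chloro in place of trifluoromethyl on an aromatic carbon. Compound 2 was reported as "not active" (no number reported), with no number given.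

The unmeasured compound 4, `CC1(c2ccccc2)CC(=O)N(CC(=O)N2CCN(c3ncccn3)CC2)C1=O`, differs from compound 1 by pyrimidin-2-yl in place of 3-(trifluoromethyl)phenyl on an amine nitrogen in a ring. No measured step touches this change: the one step shown, no change at the digits printed from compound 1 to compound 3 (within the scatter), exchanges only a substituent on the aromatic ring and leaves the ring itself in place, so it does not tell how replacing the whole ring will act. With nothing pointing either way, the expectation for compound 4 is no change beyond the scatter, no change at the digits printed from compound 1 to compound 4 (within the scatter), and compound 4 is estimated at 300 mg/kg, within 100 mg/kg to 600 mg/kg. Because compound 2 gave "not active" (no number reported), a report of no activity for compound 4 remains a real possibility.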

Compound 4, minimum effective dose: "not active" (no number reported)
Nothing numeric was reported for compound 4, so the estimate cannot be set against anything.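

Among the compounds shown here, compound 4 was reported only as "not active" in this assay, without a number, so no step from compound 1 to compound 4 can be read, and no measured property bears on this result. The compounds shown leave open how far compound 4 lies from compound 1, and whether the pyrimidin-2-yl ring nitrogens or the absent trifluoromethyl group matter.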